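Swapping the Aryl Group on an Acyl Compound

The source may hold more compounds than are shown below. What is called first, only, known or untested is meant among the compounds shown, and "the series" means these compounds.

So far three compounds have been measured in a functional assay on HCC1806 cells (Homo sapiens) for inhibition, read by sulforhodamine B assay, tested at 10 uM; a higher number here means more inhibition at the concentration tested (going by the name of the read-out), a lower number less inhibition:

Compound 1, `COC(=O)CC(=O)N1N=C(c2ccc(N3CCN(C)CC3)cc2)CC1c1ccc(N(C)C)cc1`: -8.3%
Compound 2, `CN1CCN(c2ccc(C3=NN(S(=O)(=O)c4ccc(Br)cc4)C(c4ccc(N(C)C)cc4)C3)cc2)CC1`: 87.1%
Compound 3, `CN1CCN(c2ccc(C3=NN(S(=O)(=O)c4ccc(C#N)cc4)C(c4ccc(N(C)C)cc4)C3)cc2)CC1`: 99.8%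

Compound 1 gives the lowest of the three numbers. Its nearest neighbour is reached by the step of a number 95.4 percentage points higher from compound 1 to compound 2 (beyond the scatter), and the furthest by a number 108.1 percentage points higher from compound 1 to compound 3 (beyond the scatter). Between the two sulfonyl compounds the step is smaller, a number 12.7 percentage points higher from compound 2 to compound 3 (beyond the scatter).

Compound 4, `COC(=O)CC(=O)N1N=C(c2ccc(-n3cncn3)cc2)CC1c1ccc(N(C)C)cc1`, keeps the acyl group on the ring nitrogen exactly as in compound 1 and differs elsewhere: 1H-1,2,4-triazol-1-yl in place of 4-methylpiperazin-1-yl on an aromatic carbon. Within the data shown here, every measured step concerns the group on the ring nitrogen or the substituent on the sulfonyl aryl ring; no measured step touches the place that changes here, so none of them bears on it. The only anchor is therefore the value of compound 1 itself, and the change from compound 1 to compound 4 is expected to give no step beyond the scatter, a number 13.3 percentage points higher from compound 1 to compound 4 (beyond the scatter). Compound 4 is thus estimated at 5% in this assay, with a range from -20% to 35%.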

Compound 4, a percentage reported as inhibition, at one concentration (the size of the read-out at that concentration, not a potency): -7.8%
Estimate against measurement, compound 4: 12.8 percentage points above; low and high end bracket the measured number.
By their numbers in this assay, from the lowest: compounds 1 and 4 (each within the scatter of the next); then compound 2; then compound 3.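

In this assay, among these compounds, the exchange of 4-methylpiperazin-1-yl for 1H-1,2,4-triazol-1-yl on the aromatic carbon gives a number 0.5 percentage points higher from compound 1 to compound 4 (within the scatter), the first reading of any change at this place. With the acyl group held on the ring nitrogen, a six-membered non-aromatic ring and a five-membered aromatic ring here cannot be told apart by this read-out. Nothing in the data shown explains this result.

Going by these compounds, the reading covers only compounds that carry this acyl group, so it remains open whether 1H-1,2,4-triazol-1-yl would match 4-methylpiperazin-1-yl with (4-bromophenyl)sulfonyl or (4-cyanophenyl)sulfonyl on the ring nitrogen. Also open, on these data alone, is what a morpholin-4-yl group or a carboxylic acid at this place would give in this assay.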